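Thioether to Benzothiophene: Expected Cytotoxicity of Compound 3

The source may hold more compounds than are shown below. What is called first, only, known or untested is meant among the compounds shown, and "the series" means these compounds.

Compound 1 `CCC(CC)O[C@@H]1C=C(C(=O)O)C[C@H](NCc2ccc(Cc3ccccc3)cc2)[C@H]1NC(C)=O`: > 200000 nM in an ADME assay on cells (Fibroblast, Gallus gallus) for cytotoxicity, read by CCK-8 assay, with a stated time of 48 h (on this read-out lower numbers stand for higher toxicity in this test and higher numbers for lower toxicity in this test), a limit of the assay rather than a number.
Compound 2 `CCC(CC)O[C@@H]1C=C(C(=O)O)C[C@H](NCc2ccc(SCC(C)C)cc2)[C@H]1NC(C)=O`: > 200000 nM in this assay, likewise a limit.

Both measured compounds share the same core and differ only in one group on the aromatic ring. The step that the two limits leave unreadable from compound 1 to compound 2 cannot be read, since both values are limits. Compound 2 therefore stands at the edge of what the assay reports, together with compound 1, as both values sit at the limit of > 200000 nM in this assay, at which 2 of the 2 values shown sit. Nothing in these numbers ranks compound 2 against compound 1.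

Compound 3 `CCC(CC)O[C@@H]1C=C(C(=O)O)C[C@H](NCc2ccc(-c3ccc4sccc4c3)cc2)[C@H]1NC(C)=O` is not yet measured. It differs from compound 2 by 1-benzothiophen-5-yl in place of isobutylsulfanyl on an aromatic carbon. Going by the values given here, the only measured step that bears on this change is the one from compound 1 to compound 2, and its size is not readable. No step beyond the usual scatter in this assay is therefore expected. Compound 3 is expected to stay at the limit, estimated at 200000 nM, within 100000 nM to 400000 nM. The expected step is a number no higher from compound 2 to compound 3 (the limit leaves the size open).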

Compound 3, half-maximal cytotoxic concentration: > 200000 nM
Compound 3: no number, only a limit (the forecaster's own chance of this, stated with the estimate: 85%); the middle value lies on the limit itself.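

Compound 1, compound 2 and compound 3 each give only a limit in this assay, so no step among them can be read: the limit of > 200000 nM in this assay, at which 3 of the 3 values shown sit.

The compounds shown leave open how far apart these three truly lie, and which change to the group on the aromatic ring, if any, would give a readable number in this assay.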